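Swapping the aryl group on the shared core of compound 3

The source may hold more compounds than are shown below. What is called first, only, known or untested is meant among the compounds shown, and "the series" means these compounds.

Compound 3, `CCCS(=O)(=O)Nc1ccc(F)c(C(=O)c2n[nH]c3ncc(-c4ccc(Cl)c(C(F)(F)F)c4)cc23)c1F`, stands second highest of the three numbers measured in an assay for binding affinity to dual specificity mitogen-activated protein kinase kinase 4 (Homo sapiens), read by KINOMEscan, tested at 100 nM; on this read-out higher numbers stand for a weaker effect at the one concentration tested and lower numbers for a stronger effect: compound 3 gives 15%. Its nearest neighbour is compound 1, `CCCS(=O)(=O)Nc1ccc(F)c(C(=O)c2n[nH]c3ncc(-c4ccc(OC)cc4)cc23)c1F`, which gives 4.2%, and the furthest is compound 2, `CCCS(=O)(=O)Nc1ccc(F)c(C(=O)c2n[nH]c3ncc(-c4ccc(Cl)c(Cl)c4)cc23)c1F`, which gives 45%. Compound 4, `CCCS(=O)(=O)Nc1ccc(F)c(C(=O)c2n[nH]c3ncc(-c4ccc(NS(C)(=O)=O)cc4)cc23)c1F`, carries the change (4-(methanesulfonamido)phenyl in place of 4-chloro-3-(trifluoromethyl)phenyl on an aromatic carbon). Among the compounds with values here, two measured steps bear on this position of the shared core: a number 10.8 percentage points higher from compound 1 to compound 3 (beyond the scatter), and a number 30 percentage points lower from compound 2 to compound 3 (beyond the scatter). Both show that the group on this aromatic carbon moves the read-out well beyond the scatter, and the group bearing an oxygen substituent in compound 1 gave the lowest number. A sulfonamide group entering here is therefore expected to push the number downward, as a number 7 percentage points lower from compound 3 to compound 4 (within the scatter). Compound 4 is estimated at 8%, within a range from 2% to 30%.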

Compound 4, a percentage reported as activity, at one concentration (the size of the read-out at that concentration, not a potency): 0.85%
Estimate against measurement, compound 4: 7.2 percentage points above; the measured number lies below the stated range.
By their numbers in this assay, from the lowest: compounds 4 and 1 (each within the scatter of the next); then compound 3; then compound 2.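

In this assay, 4-(methanesulfonamido)phenyl gives a number 14.2 percentage points lower from compound 3 to compound 4 (beyond the scatter) and a number 44.2 percentage points lower from compound 2 to compound 4 (beyond the scatter) so it outperforms both chlorine-bearing aryl groups at this position. Methanesulfonamido in place of methoxy gives a number 3.4 percentage points lower from compound 1 to compound 4 (within the scatter) so two different groups on this phenyl ring share a low number and cannot be ranked against each other. Nothing available explains why these groups differ from the chlorine-bearing ones.

From the compounds shown here alone, it remains open whether an amine or a carboxylic acid on this phenyl ring would keep the number as low. A longer chain in place of the methyl of the methanesulfonamido group is equally untested by these compounds.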